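Swapping the sulfonamide substituent in a kinase inhibitor series

A few compounds are considered here, and "the series" means these few. Any claim that something is new, unique, unknown or untested is made for them only; others in the source may bear on it.

Measured compounds:
compound 1, `CC[C@@H]1C(=O)N(C)c2cnc(Nc3ccc(S(=O)(=O)NC4CCCC4)cc3)nc2N1C1CCCC1`, 23.9 nM
compound 2, `CC[C@@H]1C(=O)N(C)c2cnc(-n3ccc4cc(C(=O)NC)ccc43)nc2N1C1CCCC1`, 8.6 nM

Of the compounds shown here, two sharing one core have been measured in an assay for inhibition of serine/threonine-protein kinase PLK2 (Homo sapiens), read by FRET and Z'-LYTE, with a stated time of 1 h; a lower number here means a stronger inhibitor, a higher number a weaker inhibitor. Compound 1, with a cyclopentylsulfamoyl group, gives 23.9 nM, the higher of the two numbers. Compound 2 gives 8.6 nM, a lower number that lies beyond the scatter of repeat measurement, so compound 2 is the stronger inhibitor of the pair.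

Compound 3, `CC[C@@H]1C(=O)N(C)c2cnc(Nc3ccc(S(=O)(=O)NCCCO)cc3)nc2N1C1CCCC1`, has not been measured. It differs from compound 1 only at the sulfonamide: 3-hydroxypropyl in place of cyclopentyl on a sulfonamide nitrogen. Among the compounds with values here, no measured pair shows what such a change does on this core, so the expectation rests on compound 1 alone. The account expects a small step from compound 1 to compound 3, towards a somewhat higher number or none beyond the scatter, a 1.5-fold higher number from compound 1 to compound 3 (0.17 log units; within the scatter). Compound 3 is therefore estimated at 35 nM, within a range of 12 nM to 100 nM.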

Compound 3, half-maximal inhibitory concentration: 8.16 nM
Compound 3: the middle estimate sits 4.3-fold (0.63 log units) above what was measured, and the stated range ends above it.
By their numbers in this assay, from the lowest: compounds 3 and 2 (each within the scatter of the next); then compound 1.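

In this assay the change on the sulfonamide nitrogen gives a 2.9-fold lower number from compound 1 to compound 3 (0.47 log units; beyond the scatter) and is the first change in one place among these compounds, showing that the group on this nitrogen bears on the number. The direction also shows that the shared core can lose the cyclopentyl ring and take an open chain, 3-hydroxypropyl, with no rise in the number. This single step, however, swaps a ring of carbon only for a chain and brings in an oxygen at the same time, so it cannot separate these two differences.

A plain propyl chain, a shorter 2-hydroxyethyl chain, or a chain ending in an amine or a carboxylic acid would be needed to tell which difference carries the step. Nothing available gives a cause for the step.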